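Acrylamide chain extension on the shared core

The source may report more compounds than this note shows. Statements on the series, on what has been measured and on what is new or still open speak of the compounds shown alone.

Measured compounds:
compound 1 `C=CC(=O)Nc1cc2c(N3CCc4ccccc43)ncnc2cc1O[C@@H]1CCOC1` — 2710 nM
compound 2 `C/C=C/C(=O)Nc1cc2c(N3CCc4ccccc43)ncnc2cc1O[C@@H]1CCOC1` — 5220 nM

In a functional assay on PC-3 cells (Homo sapiens) for antiproliferative activity, read by MTT assay, with a stated time of 72 h (on this read-out higher numbers stand for weaker inhibition and lower numbers for stronger inhibition), compound 1 gives 2710 nM and compound 2 gives 5220 nM. The step of a 1.9-fold higher number from compound 1 to compound 2 (0.28 log units; within the scatter) is the only one measured so far, and it is within the scatter, so the two compounds cannot be ordered on these numbers; compound 2 simply carries the higher of the two values.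

Compound 3 `CC(C)/C=C/C(=O)Nc1cc2c(N3CCc4ccccc43)ncnc2cc1O[C@@H]1CCOC1` is not yet measured. It differs from compound 2 by isopropyl in place of methyl on a double-bonded chain carbon bound to a double-bonded chain carbon. Within the data shown here, the only step that bears on this is the one from compound 1 to compound 2, which also grew the chain on the carbonyl carbon and stayed within the scatter. Among the measured compounds shown here, compound 3 grows the same chain further, and no measured step covers a branch of that size; the expectation is therefore a number near that of compound 2, with a slight lean toward a higher value in this assay, expected as a 1.3-fold higher number from compound 2 to compound 3 (0.13 log units; within the scatter).

Compound 3 is estimated at 7000 nM in this assay, with a range from 3000 nM to 16000 nM.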

Compound 3, half-maximal inhibitory concentration: 11200 nM
The estimate for compound 3 lay 1.6-fold (0.20 log units) below the measured number, and the stated range covers the measured number.
By their numbers in this assay, from the lowest: compounds 1 and 2 (each within the scatter of the next); then compound 3.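

In this assay, among these compounds, isopropyl in place of methyl on a double-bonded chain carbon bound to a double-bonded chain carbon gives a 2.1-fold higher number from compound 2 to compound 3 (0.33 log units; beyond the scatter), the first change at this position that lies beyond the scatter. Measured from the unextended acrylamide, the 3-methylbut-1-en-1-yl group on the carbonyl carbon gives a 4.1-fold higher number from compound 1 to compound 3 (0.62 log units; beyond the scatter), whereas the smaller extension gave only a 1.9-fold higher number from compound 1 to compound 2 (0.28 log units; within the scatter); across these three compounds, none goes against a higher number with the larger group, although compound 1 and compound 2 cannot be ordered. The data at hand offer no measurement that would account for this rise.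

The three compounds do not separate branching from chain length, so an unbranched longer chain such as pent-1-en-1-yl on the same carbonyl carbon would be needed to tell whether the isopropyl branch itself matters. They also leave open how this position responds to a group other than a hydrocarbon, such as a dimethylaminomethyl group in place of the methyl of compound 2, and whether any change here can bring the number below that of compound 1.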